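Aryl substituent steps on a shared core

The compounds below may be only part of what the source reports. "The series", "measured", "known", "first", "only" and "open" are said of these compounds alone.

Compound 1 `Cc1c(O)ccc2c1[C@H](Cn1cc(-c3ccc(Cl)cc3)nn1)[C@@]13CC(=O)[C@@](C)(CC[C@@H]21)C3`, compound 2 `Cc1c(O)ccc2c1[C@H](Cn1cc(-c3ccc(C(F)(F)F)cc3)nn1)[C@@]13CC(=O)[C@@](C)(CC[C@@H]21)C3` and compound 3 `Cc1ccc(-c2cn(C[C@H]3c4c(ccc(O)c4C)[C@@H]4CC[C@@]5(C)C[C@]43CC5=O)nn2)cc1` share one core and differ only in the group carried on the six-membered aromatic ring of carbon only: chloro, trifluoromethyl and methyl. In a functional assay on SMMC-7721 cells (Homo sapiens) for cytotoxicity, read by MTT assay, with a stated time of 4 days (a lower number here means a stronger inhibitor, a higher number a weaker inhibitor), compound 1 returns only the limit of the assay, > 20000 nM. Compound 2 likewise reaches only the limit, > 20000 nM. For compound 3 the result is again the assay limit, > 20000 nM. Compound 3 therefore stands nowhere on a readable scale; it is one of three compounds sitting at the limit of > 20000 nM in this assay, at which 3 of the 3 values shown sit. The steps a step that the two limits leave unreadable from compound 1 to compound 2, a step that the two limits leave unreadable from compound 1 to compound 3 and a step that the two limits leave unreadable from compound 2 to compound 3 are all unreadable, the two limits hiding any difference.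

Compound 4 `COc1ccc(-c2cn(C[C@H]3c4c(ccc(O)c4C)[C@@H]4CC[C@@]5(C)C[C@]43CC5=O)nn2)cc1` differs from compound 3 by methoxy in place of methyl on an aromatic carbon. The three measured steps bear on it only in kind, each being an exchange of a single group on the same aromatic carbon, and none gives a readable size. Nothing in the series shows such an exchange moving the value out of the limit, so no step beyond the scatter is expected in this assay. The step from compound 3 to compound 4 is estimated as a step that the limit leaves unreadable from compound 3 to compound 4, an expected near-zero change. Compound 4 is expected at 30000 nM, within 10000 nM to 90000 nM, and most probably reported again as a limit.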

Compound 4, half-maximal inhibitory concentration: > 20000 nM
Compound 4: no number, only a limit; the forecaster's own chance of this, stated with the estimate: 85%; the middle value is on the limit's open side.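

No new step can be read: compound 4, like compound 1, compound 2 and compound 3, returns only a limit in this assay, so the steps among these compounds cannot be read: the limit of > 20000 nM in this assay, at which 4 of the 4 values shown sit.

The compounds shown leave open whether any group at this aromatic carbon of the shared core gives a readable value in this assay, and how the four groups would rank.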